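This account rests on a few compounds, and the source may have more. Where it says the series, first, only, none or still open, it means among the compounds named here.

Going by the values given here, in a functional assay on MCF7 cells (Homo sapiens) for antiproliferative activity, read by MTT assay, with a stated time of 72 h (a lower number here means a stronger inhibitor, a higher number a weaker inhibitor), three compounds built on the same core have numbers so far: compound 1 `COc1cccc(N(C)S(=O)(=O)C2CC3OC2C(c2ccc(NC(=O)CCCCCCC(=O)O)cc2)=C3c2ccc(O)cc2)c1` gives 39400 nM, compound 2 `CCN(c1ccc(C)cc1)S(=O)(=O)C1CC2OC1C(c1ccc(NC(=O)CCCCCCC(=O)O)cc1)=C2c1ccc(O)cc1` gives 42300 nM, and compound 3 `CCN(c1cccc(C)c1)S(=O)(=O)C1CC2OC1C(c1ccc(NC(=O)CCCCCCC(=O)O)cc1)=C2c1ccc(O)cc1` gives 31800 nM. Compound 3 therefore stands level with the other two, since its steps to both lie within the scatter.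

Compound 4 `CCN(c1ccccc1Cl)S(=O)(=O)C1CC2OC1C(c1ccc(NC(=O)CCCCCCC(=O)O)cc1)=C2c1ccc(O)cc1` changes one group of compound 3: 2-chlorophenyl in place of 3-methylphenyl on a sulfonamide nitrogen. In words, this is 2-chlorophenyl in place of 3-methylphenyl on a sulfonamide nitrogen.

The closest measured change at this place is 3-methylphenyl in place of 4-methylphenyl, which gave a 1.3-fold lower number from compound 2 to compound 3 (0.12 log units; within the scatter). Broader swaps of the group on the sulfonyl sulfur gave a 1.1-fold higher number from compound 1 to compound 2 (0.03 log units; within the scatter) and a 1.2-fold lower number from compound 1 to compound 3 (0.09 log units; within the scatter). Among the compounds with values here, all three steps are small, but no measured compound carries a 2-chlorophenyl group, so the new group itself is untested.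

No step beyond the scatter is expected in this assay. The estimate means a 1.1-fold higher number from compound 3 to compound 4 (0.03 log units; within the scatter), an expected change too small to distinguish from repeat measurements. For compound 4, the estimated value is 34000 nM, with an expected range from 17000 nM to 70000 nM.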

Compound 4, half-maximal inhibitory concentration: 33300 nM
For compound 4 the middle estimate is 1.0-fold (0.01 log units) above the measured one; measured number inside the range.
By their numbers in this assay, from the lowest: compounds 3, 4, 1 and 2 (each within the scatter of the next).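

In this assay the sulfonamide nitrogen now carries a ring with a chlorine rather than a methyl, and 2-chlorophenyl in place of 3-methylphenyl gives a 1.0-fold higher number from compound 3 to compound 4 (0.02 log units; within the scatter) while 2-chlorophenyl in place of 4-methylphenyl gives a 1.3-fold lower number from compound 2 to compound 4 (0.10 log units; within the scatter) on the same nitrogen. Changing the whole amino group on the sulfonyl sulfur gives a 1.2-fold lower number from compound 1 to compound 4 (0.07 log units; within the scatter) and so also stays level, which means that among these four compounds a chlorine-bearing ring fits the same narrow band as the rings carrying methyl or methoxy. Nothing available explains why the numbers stay together.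

The compounds shown leave open whether an amine on this ring, or a longer chain in place of the ethyl, would move the number beyond the scatter. All four also share the core and the chain ending in a carboxylic acid, so the effect of a hydroxamic acid at that chain end remains an open question.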